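Replacing the aryl group on the ethenyl chain of compound 1

The source may report more compounds than this note shows. Statements on the series, on what has been measured and on what is new or still open speak of the compounds shown alone.

In a functional assay on MCF7 cells (Homo sapiens) for cytotoxicity, read by MTT assay, with a stated time of 72 h (a higher number here means a weaker inhibitor, a lower number a stronger inhibitor), compound 1 `COc1cc2ncnc(Nc3ccc(F)c(Cl)c3)c2cc1NC(=O)/C=C/c1ccc(F)cc1Cl` is recorded as "not active" (no number reported) and so has no single number. Going by the values given here, the only numeric reference is compound 2 `COc1cc(/C=C/C(=O)Nc2cc3c(Nc4ccc(F)c(Cl)c4)ncnc3cc2O[C@H]2CCOC2)cc(OC)c1OC` at 28400 nM in this assay. Compound 3 `COc1ccc(/C=C/C(=O)Nc2cc3c(Nc4ccc(F)c(Cl)c4)ncnc3cc2OC)cc1` keeps the core of compound 1 and carries one change (4-methoxyphenyl in place of 2-chloro-4-fluorophenyl on a double-bonded chain carbon bound to a double-bonded chain carbon). In this assay a small step towards stronger inhibition is expected from the unquantified standing of compound 1, though its size cannot be computed, and the result is expected to remain weak, close to compound 2 (28400 nM) and within the usual scatter of it. The estimate for compound 3 is 25000 nM (expected range 8000 nM to 80000 nM).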

Compound 3, half-maximal inhibitory concentration: "not active" (no number reported)
No number was reported for compound 3; the estimate stays without a comparison.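

In this assay compound 1 and compound 3 both carry no number, so no new step can be read between them. No evidence bears on this result. The compounds shown leave open how 2-chloro-4-fluorophenyl and 4-methoxyphenyl compare in size of effect.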